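The compounds below may be only part of what the source reports. "The series", "measured", "known", "first", "only" and "open" are said of these compounds alone.

Measured so far in a functional assay on HepG2 cells (Homo sapiens) for inhibition, read by MTT assay, with a stated time of 48 h; on this read-out higher numbers stand for weaker inhibition and lower numbers for stronger inhibition:
compound 1, `O=C(Nc1ccc(N2CCN(c3ccc(OC[C@@H]4CO[C@@](Cn5cncn5)(c5ccc(Cl)cc5Cl)O4)cc3)CC2)cc1)C(/C=C/Cl)C/C=C/C(F)(F)F`, 9570 nM
compound 2, `O=C(Nc1ccc(N2CCN(c3ccc(OC[C@@H]4CO[C@@](Cn5cncn5)(c5ccc(Cl)cc5Cl)O4)cc3)CC2)cc1)c1cccc(F)c1`, 10800 nM

Going by the values given here, compound 2 holds the highest of the two numbers, but the one step between them is a 1.1-fold higher number from compound 1 to compound 2 (0.05 log units; within the scatter), so the two stand together. Compound 3, `Cc1ccc(C(=O)Nc2ccc(N3CCN(c4ccc(OC[C@@H]5CO[C@@](Cn6cncn6)(c6ccc(Cl)cc6Cl)O5)cc4)CC3)cc2)o1`, differs from compound 2 by 5-methylfuran-2-yl in place of 3-fluorophenyl on a carbonyl carbon. Among the compounds with values here, the one measured step at this position, a 1.1-fold higher number from compound 1 to compound 2 (0.05 log units; within the scatter), lies within the scatter, and nothing else bears on the change. No step beyond the scatter is therefore expected from compound 2 to compound 3 in this assay: a 1.1-fold lower number from compound 2 to compound 3 (0.03 log units; within the scatter). For compound 3 the estimate is 10000 nM, expected to fall between 4000 nM and 25000 nM.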

Compound 3, half-maximal inhibitory concentration: 8700 nM
Compound 3: the middle estimate sits 1.1-fold (0.06 log units) above what was measured; the measured number falls inside the stated range.
By their numbers in this assay, from the lowest: compounds 3, 1 and 2 (each within the scatter of the next).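

In this assay, 5-methylfuran-2-yl in place of 3-fluorophenyl on the carbonyl carbon gives a 1.2-fold lower number from compound 2 to compound 3 (0.09 log units; within the scatter), and in place of 1-(2-chloroethenyl)-5,5,5-trifluoropent-3-en-1-yl it gives a 1.1-fold lower number from compound 1 to compound 3 (0.04 log units; within the scatter). Going by these compounds alone, the position now holds a five-membered aromatic ring with one hetero atom and one hydrogen-bond acceptor, and no step among the three compounds leaves the scatter. Nothing available explains this flat result. Going by these compounds, whether any group here moves the number beyond the scatter stays open; a phenyl ring carrying an amine or a carboxylic acid would test that.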